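The source may hold more compounds than are shown below. What is called first, only, known or untested is meant among the compounds shown, and "the series" means these compounds.

Measured so far in a functional assay on DU-145 cells (Homo sapiens) for inhibition, read by MTT assay, with a stated time of 24 h; a lower number here means a stronger inhibitor, a higher number a weaker inhibitor:
Compound 1 `CCOC(=O)C1=Cc2ccccc2OC1(OCc1cn(-c2ccc(F)cc2)nn1)C(F)(F)F`: 8900 nM
Compound 2 `CCOC(=O)C1=Cc2ccccc2OC1(OCc1cc(-c2ccc(C)cc2)no1)C(F)(F)F`: only a limit of the assay, > 150000 nM
Compound 3 `Cc1ccc(-c2cc(COC3(C(F)(F)F)Oc4ccccc4C=C3C(=O)O)on2)cc1`: 41400 nM

Compound 1 holds the lowest of the two numbers; compound 3 sits higher, beyond the scatter, and compound 2 contributes only a limit (the limit of > 150000 nM in this assay, at which 1 of the 3 values shown sits). For the measured compounds named here, the single measured step, an at least 3.6-fold lower number from compound 2 to compound 3 (0.55 log units; beyond the scatter), concerns hydrogen in place of ethyl on an oxygen next to a carbonyl group and says nothing about the group on the aromatic nitrogen.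

Compound 4 `CCOC(=O)C1=Cc2ccccc2OC1(OCc1cn(CC(=O)Nc2ccccc2F)nn1)C(F)(F)F` differs from compound 1 by ((2-fluorophenyl)carbamoyl)methyl in place of 4-fluorophenyl on an aromatic nitrogen. Going by the values given here, no measured step bears on this change, so no step beyond the scatter is expected: a 1.1-fold higher number from compound 1 to compound 4 (0.05 log units; within the scatter). Compound 4 is therefore estimated at 10000 nM, with a range from 3000 nM to 40000 nM.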

Compound 4, half-maximal inhibitory concentration: 33900 nM
For compound 4 the middle estimate is 3.4-fold (0.53 log units) below the measured one; low and high end bracket the measured number.
By their numbers in this assay, from the lowest: compound 1; then compounds 4 and 3 (each within the scatter of the next). At a limit, above all of these: compound 2.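

In this assay, the group on the aromatic nitrogen of the five-membered ring is now seen to matter: ((2-fluorophenyl)carbamoyl)methyl in place of 4-fluorophenyl gives a 3.8-fold higher number from compound 1 to compound 4 (0.58 log units; beyond the scatter). The longer group, with its amide hydrogen, therefore brings no gain over 4-fluorophenyl at this position. Nothing shown accounts for the size of this step.

Still open, going by these compounds, is whether the step follows from the carbamoylmethyl link or from 2-fluorophenyl replacing 4-fluorophenyl. Also open, on these data alone, is how an amine or a carboxylic acid at the end of a longer chain on this nitrogen would read.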